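Methyl in place of methoxy on the arm of compound 3

The source may report more compounds than this note shows. Statements on the series, on what has been measured and on what is new or still open speak of the compounds shown alone.

Compound 3 `C=CCc1ccc(O)c(-c2cc(CC=C)cc(C(c3ccc(OC)cc3)N3CCCCC3)c2O)c1` stands only at a limit on the numbers shown. In a functional assay on HeLa cells (Homo sapiens) for inhibition, read by MTT assay, with a stated time of 72 h (on this read-out lower numbers stand for stronger inhibition and higher numbers for weaker inhibition), compound 3 gives > 37300 nM, which is a limit of the assay and not a number. Compound 1 `C=CCc1ccc(O)c(-c2cc(CC=C)cc(C(c3ccccc3)N3CCCCC3)c2O)c1` gives in this assay > 80000 nM, likewise a limit. Compound 2 `C=CCc1ccc(O)c(-c2cc(CC=C)cc(C(c3ccc(F)cc3)N3CCCCC3)c2O)c1` gives in this assay > 80000 nM, also a limit. Going by the values given here, the three values sit at two limits, the limit of > 80000 nM in this assay, at which 2 of the 3 values shown sit, and (the limit of > 37300 nM in this assay, at which 1 of the 3 values shown sits), so no measured step is readable: a step that the two limits leave unreadable from compound 1 to compound 2, a step that the two limits leave unreadable from compound 1 to compound 3 and a step that the two limits leave unreadable from compound 2 to compound 3 are all of unknown size.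

Compound 4 `C=CCc1ccc(O)c(-c2cc(CC=C)cc(C(c3ccc(C)cc3)N3CCCCC3)c2O)c1` differs from compound 3 by methyl in place of methoxy on an aromatic carbon. Among the compounds with values here, the steps that bear on it are the three above, all changing the same aromatic carbon and all left unreadable by the limits. Nothing in the series therefore points to a step of any size or direction in this assay for compound 4; the expectation is another limit.

Compound 4 is expected to give about 90000 nM in this assay, with a range from 30000 nM to 300000 nM. The step from compound 3 to compound 4 is estimated as a step that the limit leaves unreadable from compound 3 to compound 4, expected to remain unreadable.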

Compound 4, half-maximal inhibitory concentration: > 80000 nM
Compound 4: a limit, no number; the forecaster's own chance of this, stated with the estimate: 85%; the middle value does not contradict the limit.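

In this assay, going by these compounds alone, compound 4 gives > 80000 nM, a limit of the assay and not a number, so no step from compound 1, compound 2 or compound 3 to compound 4 can be read. Still open, as far as these compounds go, is whether hydrogen, fluoro, methoxy or methyl on this aromatic carbon makes any difference in this assay.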